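The source may hold more compounds than are shown below. What is called first, only, known or untested is meant among the compounds shown, and "the series" means these compounds.

In a functional assay on BV-2 cells (Mus musculus) for inhibition, read by ELISA, with a stated time of 16 h (on this read-out higher numbers stand for weaker inhibition and lower numbers for stronger inhibition), compound 1 `Cc1cc(C)c(N2CCN(c3ncccn3)CC2)nn1` gives only the limit > 100000 nM. Compound 2 `COc1cccc(-c2cc(C)c(N3CCN(c4ncccn4)CC3)nn2)c1` gives 2600 nM, the lowest of the two numbers on hand, and compound 3 `Cc1cc(-c2ccc(C(F)(F)F)cc2)nnc1N1CCN(c2ncccn2)CC1` gives 37400 nM, a higher number beyond the scatter. Within the data shown here, the single measured step, an at least 38-fold lower number from compound 1 to compound 2 (1.58 log units; beyond the scatter), is the only one bearing on the present change; its size is a lower bound, because the limit of > 100000 nM in this assay, at which 1 of the 3 values shown sits, caps what compound 1 can show. Compound 4 `Cc1cc(-c2ccncc2)nnc1N1CCN(c2ncccn2)CC1` differs from compound 2 by pyridin-4-yl in place of 3-methoxyphenyl on an aromatic carbon. A six-membered aromatic ring is kept, so no return to the limit of compound 1 is expected, yet compound 3 shows another aryl group yielding a much higher number than compound 2. A moderate rise is therefore expected, a 3.1-fold higher number from compound 2 to compound 4 (0.49 log units; beyond the scatter). Compound 4 is estimated at 8000 nM, within 2000 nM to 35000 nM.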

Compound 4, half-maximal inhibitory concentration: > 100000 nM
Compound 4: a limit, no number (the forecaster's own chance of this, stated with the estimate: 10%); middle value at least 12-fold (1.09 log units) from the limit.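

Pyridin-4-yl in place of 3-methoxyphenyl gives an at least 38-fold higher number from compound 2 to compound 4 (1.58 log units; beyond the scatter), so a six-membered aromatic ring on this carbon is not enough on its own. Compound 4 gives a limit, not a number, so the size of this step is only a lower bound: the limit of > 100000 nM in this assay, at which 2 of the 4 values shown sit.
Compound 1 and compound 4 both sit at limits, and the step between them cannot be read.

On these data alone, whether the methoxy group or the carbon-only ring carries the activity of compound 2 stays open. A plain phenyl group or a methoxy-bearing pyridine ring on this carbon would bear on that.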